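Fluoro for Nitro on the Benzyl Arm

The source may hold more compounds than are shown below. What is called first, only, known or untested is meant among the compounds shown, and "the series" means these compounds.

Compound 1 `COc1cc(N)c(Cl)cc1NC(=O)C1CCN(C/C=C/c2ccccc2)CC1`, a limit in a functional assay on the whole organism for antagonist activity, with Mus musculus as the target; a higher number here means that more compound is needed for the effect, a lower number that less compound is needed: > 10 mg/kg.
Compound 2 `COc1cc(N)c(Cl)cc1NC(=O)C1CCN(Cc2cccc(C#N)c2)CC1`, a limit in this assay: > 4 mg/kg.
Compound 3 `COc1cc(N)c(Cl)cc1NC(=O)C1CCN(Cc2ccc([N+](=O)[O-])cc2)CC1`, a limit in this assay: > 4 mg/kg.

Compound 3 stands only at a limit, and the two other values are limits as well, so a step that the two limits leave unreadable from compound 1 to compound 3 and a step that the two limits leave unreadable from compound 2 to compound 3 are unreadable, as is a step that the two limits leave unreadable from compound 1 to compound 2. The change to compound 4 `COc1cc(N)c(Cl)cc1NC(=O)C1CCN(Cc2ccc(F)cc2)CC1` is fluoro in place of nitro on an aromatic carbon. For the measured compounds named here, no measured step bears on this change with a readable size; the only evidence is the limit of > 10 mg/kg in this assay, at which 1 of the 3 values shown sits, and (the limit of > 4 mg/kg in this assay, at which 2 of the 3 values shown sit), which give no direction. Compound 4 is therefore expected near 3 mg/kg, from 0.5 mg/kg to 15 mg/kg. The estimated step of an at least 1.3-fold lower number from compound 3 to compound 4 (0.12 log units; that floor lies within the scatter) cannot be set against any measured size.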

Compound 4, dose for half-maximal effect: 0.6 mg/kg
The estimate for compound 4 lay 5.0-fold (0.70 log units) above the measured number; the range from low to high includes it.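

Compound 4 gives the series its first readable steps in this assay: fluoro in place of nitro on an aromatic carbon, para to a large group, brings an at least 6.6-fold lower number from compound 3 to compound 4 (0.82 log units; beyond the scatter). The 4-fluorophenyl arm also gives an at least 6.6-fold lower number from compound 2 to compound 4 (0.82 log units; beyond the scatter) against the 3-cyanophenyl arm and an at least 16-fold lower number from compound 1 to compound 4 (1.22 log units; beyond the scatter) against the 2-phenylethenyl arm, whereas the steps among the first three compounds cannot be read. Nothing measured here accounts for these gains. From the compounds shown here alone, how a chloro or a methoxy group would compare at this place remains open. So does whether fluoro would give the same result on another aromatic carbon.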